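The source may report more compounds than this note shows. Statements on the series, on what has been measured and on what is new or still open speak of the compounds shown alone.

Measured so far in an ADME assay on MRC5 cells (Homo sapiens) for cytotoxicity, read by fluorescence and resazurin assay, with a stated time of 3 days; a higher number here means a weaker inhibitor, a lower number a stronger inhibitor:
compound 1 `Cc1cn(C2CCN(Cc3cc(Oc4cccc(Cl)c4)ccn3)CC2)c(=O)[nH]c1=O`: > 64000 nM
compound 2 `Cc1cn(C2CCN(Cc3cccc(Oc4cccc(F)c4)c3)CC2)c(=O)[nH]c1=O`: > 64000 nM
compound 3 `Cc1cn(C2CCN(Cc3ccnc(Oc4ccccc4)c3)CC2)c(=O)[nH]c1=O`: > 64000 nM

Compound 2 gives only a limit, > 64000 nM, and not a number. The other two entries are limits as well, so the series stands at the limit of > 64000 nM in this assay, at which 3 of the 3 values shown sit. Within the data shown here, no measured step connects these compounds, and the size of any change has no direct precedent here.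

Compound 4 `Cc1cn(C2CCN(Cc3cccc(Oc4ccc(Cl)c(Cl)c4)c3)CC2)c(=O)[nH]c1=O` keeps the rest of compound 2 and carries 3,4-dichlorophenyl in place of 3-fluorophenyl on an oxygen on an aromatic ring.

In this assay, the expectation is a modest move toward stronger inhibition or no change beyond the scatter, and a further reading at the limit is quite possible. Among the measured compounds shown here, the expected size of the move, an at least 1.6-fold lower number from compound 2 to compound 4 (0.20 log units; that floor lies within the scatter), is only a rough estimate with no measured step behind it. The estimate for compound 4 is 40000 nM, with an expected range of 15000 nM to 64000 nM.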

Compound 4, half-maximal inhibitory concentration: 6100 nM
Beside the measured number, compound 4's estimate is 6.6-fold (0.82 log units) above it; the whole stated range lies above it.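

In this assay, 3,4-dichlorophenyl in place of 3-fluorophenyl on an oxygen on an aromatic ring gives an at least 10-fold lower number from compound 2 to compound 4 (1.02 log units; beyond the scatter), so a change at this position alone can produce a large shift in the read-out. With the rest of the structure held as in compound 2, compound 4 gives a measured number, 6100 nM, and not a limit. It is the only compound shown that gives a number, and the rest of the series stays flat: the limit of > 64000 nM in this assay, at which 3 of the 4 values shown sit.

The compounds shown leave open whether one chlorine of the 3,4-dichlorophenyl group would be enough for this step, or whether both are needed. They also leave open whether a methoxy group or a carboxylic acid on the same phenyl ring would give a measured number or a reading at the limit.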